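The compounds below may be only part of what the source reports. "The series", "measured", "known", "first", "only" and "open" are said of these compounds alone.

Measured compounds in a functional assay on COLO 205 cells (Homo sapiens) for cytotoxicity, read by sulforhodamine B assay, with a stated time of 48 h, tested at 100 uM; a higher number here means a weaker effect of the compound at the concentration tested, a lower number a stronger effect:
- compound 1 `COc1cc(-c2cc(/C=C/C(=O)c3ccc(N)cc3)[nH]n2)cc(OC)c1OC` gives -78%
- compound 2 `COc1ccc(-c2cc(/C=C/C(=O)c3ccc(N)cc3)[nH]n2)cc1OC` gives -78%

Compound 1 stands level with compound 2 at the digits shown; the one recorded step, no change at the digits printed from compound 1 to compound 2 (within the scatter), changed nothing beyond the scatter, so the series so far gives no lever at all on this assay.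

Compound 3 `COc1cc(-c2cc(/C=C/C(=O)c3ccc(F)c(F)c3)[nH]n2)cc(OC)c1OC` has not yet been measured. It differs from compound 1 as follows:
3,4-difluorophenyl in place of 4-aminophenyl on a carbonyl carbon

Within the data shown here, no measured step touches this part of the molecule: the only recorded step concerns the methoxy on the other aromatic ring, and it was flat. The expectation for compound 3 therefore rests on compound 1 alone, with a wide margin. A step of a number 18 percentage points higher from compound 1 to compound 3 (beyond the scatter) is expected, which is no more than a guess toward a somewhat weaker effect. Compound 3 is estimated at -60%, within -90% to 0%.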

Compound 3, a percentage reported as activity, at one concentration (the size of the read-out at that concentration, not a potency): -99%
The estimate for compound 3 lay 39 percentage points above the measured number; measured number outside the range, below it.
By their numbers in this assay, from the lowest: compound 3; then compounds 1 and 2 (each within the scatter of the next).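

In this assay, among these compounds, the group on the carbonyl carbon is the first place to shift the read-out: 3,4-difluorophenyl in place of 4-aminophenyl gives a number 21 percentage points lower from compound 1 to compound 3 (beyond the scatter) and so goes further than the earlier methoxy step, which showed no change at the digits printed from compound 1 to compound 2 (within the scatter) on the same scale. The swap removes the amino group and brings in two fluorines at once, so this single step cannot separate the loss of one from the gain of the other. No supporting measurement bears on why the number moved.

As far as these compounds go, whether a single fluorine, a chlorine or a carboxylic acid on that phenyl ring would give a similar read-out remains open. Also open, from the compounds shown here alone, is whether the flat methoxy step holds with 3,4-difluorophenyl in place, and how the single-concentration read-out relates to potency.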